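The compounds below may be only part of what the source reports. "The series", "measured", "known", "first", "only" and "open" are said of these compounds alone.

Three compounds share one core and differ only in the group carried on the sulfonamide nitrogen. In an ADME assay on the whole organism for pharmacokinetics, with Homo sapiens as the target (a higher number here means that a larger share of the oral dose reaches the circulation, a lower number that a smaller share of the oral dose reaches the circulation), compound 1 `O=C(O)c1ccccc1NS(=O)(=O)c1ccc2nc(-c3ccccc3)c(-c3ccccc3)nc2c1` gives 83.6%, compound 2 `O=S(=O)(Nc1ccc2ccccc2c1)c1ccc2nc(-c3ccccc3)c(-c3ccccc3)nc2c1` gives 100%, and compound 3 `CC(=O)c1cccc(NS(=O)(=O)c2ccc3nc(-c4ccccc4)c(-c4ccccc4)nc3c2)c1` gives 96.9%. Compound 3 thus stands second highest of the three numbers: compound 2 lies within the scatter of it, while compound 1 lies beyond the scatter below it. The measured steps read a number 16.4 percentage points higher from compound 1 to compound 2 (beyond the scatter), a number 13.3 percentage points higher from compound 1 to compound 3 (beyond the scatter) and a number 3.1 percentage points lower from compound 2 to compound 3 (within the scatter). Compound 4 `O=S(=O)(Nc1ccccc1)c1ccc2nc(-c3ccccc3)c(-c3ccccc3)nc2c1` arises from compound 3 by the change (hydrogen in place of acetyl on an aromatic carbon). No measured step removes an acetyl group, so the only guide is that exchanging naphthalen-2-yl for 3-acetylphenyl left the number within the scatter, and that both of these compounds already sit close to the highest number this kind of measurement can report. For the move to compound 4 a step of a number 1.9 percentage points lower from compound 3 to compound 4 (within the scatter) is expected, which is within the scatter. Compound 4 is therefore estimated at 95% in this assay, with a range from 80% to 100%.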

Compound 4, oral bioavailability: 100%
Estimate against measurement, compound 4: 5 percentage points below; measured number inside the range.
By their numbers in this assay, from the lowest: compound 1; then compounds 3, 2 and 4 (each within the scatter of the next).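

In this assay, taking the acetyl off its aromatic carbon gives a number 3.1 percentage points higher from compound 3 to compound 4 (within the scatter) and so leaves the bare phenyl compound within the scatter of the acetyl compound. Likewise, phenyl in place of naphthalen-2-yl on the sulfonamide nitrogen gives no change at the digits printed from compound 2 to compound 4 (within the scatter), whereas hydrogen in place of carboxy gives a number 16.4 percentage points higher from compound 1 to compound 4 (beyond the scatter), so among these four compounds only the carboxy-bearing compound 1 stands apart. Nothing measured here explains these numbers.

From the compounds shown here alone, whether an amine or a carboxylic acid on the aromatic carbon that holds the acetyl in compound 3 would stay within the scatter of compound 4 remains open. Going by these compounds, it also remains open whether the lower number of compound 1 follows the carboxy group itself or the place it occupies on the ring.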